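The source may report more compounds than this note shows. Statements on the series, on what has been measured and on what is new or still open speak of the compounds shown alone.

Working notes on the series. In a functional assay on T47D cells (Homo sapiens) for antiproliferative activity, read by MTT assay, with a stated time of 72 h (on this read-out higher numbers stand for weaker inhibition and lower numbers for stronger inhibition), compound 1 (`CCCn1ccnc1-c1cc(OC)c(OC)c(OC)c1`) reads > 100000 nM as a limit and not a number. In this assay compound 2 (`COc1cc(-c2nccn2C(C)C)cc(OC)c1OC`) reads > 100000 nM as a limit as well. Compound 3 (`COc1cc(-c2nccn2Cc2ccccc2)cc(OC)c1OC`) reads > 100000 nM and so stands only at a limit. The whole record so far is the limit of > 100000 nM in this assay, at which 3 of the 3 values shown sit, and no numerical value is yet in hand.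

Compound 4 (`COc1cc(-c2nccn2-c2ccc(Br)cc2)cc(OC)c1OC`) carries 4-bromophenyl in place of benzyl on an aromatic nitrogen, with 4-bromophenyl in place of benzyl on an aromatic nitrogen as the counted difference.

For the measured compounds named here, three measured steps bear on this change: a step that the two limits leave unreadable from compound 1 to compound 2 and a step that the two limits leave unreadable from compound 1 to compound 3 and also a step that the two limits leave unreadable from compound 2 to compound 3 and none of them supplies a size to carry over. The data therefore give no firm size for the step in this assay and only a weak hint that compound 4 stays close to the limit. Any number that does appear can only lie on the side of stronger inhibition. The expected change is an at least 1.4-fold lower number from compound 3 to compound 4 (0.15 log units; that floor lies within the scatter) as a rough estimate. For compound 4 the estimated value is 70000 nM with an expected range from 8000 nM to 100000 nM in this assay.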

Compound 4, half-maximal inhibitory concentration: 24600 nM
The estimate for compound 4 lay 2.8-fold (0.45 log units) above the measured number; the measured number falls inside the stated range.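

For the compounds shown here, compound 4 is the first compound to give a number in this assay, which shows that the group on this aromatic nitrogen can move the read-out off the limit: 4-bromophenyl in place of benzyl gives an at least 4.0-fold lower number from compound 3 to compound 4 (0.60 log units; beyond the scatter). Going by these compounds, the same change measured against the two open-chain groups gives an at least 4.0-fold lower number from compound 2 to compound 4 (0.60 log units; beyond the scatter) and an at least 4.0-fold lower number from compound 1 to compound 4 (0.60 log units; beyond the scatter), so 4-bromophenyl is set apart from benzyl, isopropyl and propyl alike, and each of these three steps is a floor whose true size stays unknown. The steps among compound 1, compound 2 and compound 3 cannot be read, and most of the record still rests on one limit: the limit of > 100000 nM in this assay, at which 3 of the 4 values shown sit.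

The step from benzyl to 4-bromophenyl removes the saturated carbon between the nitrogen and the aromatic ring and also brings in bromine, and the compounds shown do not separate these two changes. On these data alone, how an unsubstituted phenyl, a 4-chlorophenyl or a 4-methoxyphenyl on the same nitrogen would read remains open, as does whether a 4-bromobenzyl group would keep any of the step.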